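Dichloro versus monochloro purines on U-251 cells

This account rests on a few compounds, and the source may have more. Where it says the series, first, only, none or still open, it means among the compounds named here.

Of the compounds shown here, three have been measured in a functional assay on U-251 cells (Homo sapiens) for cytotoxicity, read by sulforhodamine B assay, with a stated time of 48 h; on this read-out higher numbers stand for weaker inhibition of growth and lower numbers for stronger inhibition of growth. Compound 1 `ClCc1ccccc1Cn1cnc2c(Cl)nc(Cl)nc21` gives 310 nM in this assay. Compound 2 `ClCc1ccccc1Cn1cnc2c(Cl)ncnc21` gives 2630 nM in this assay. Compound 3 `ClCc1cccc(Cn2cnc3c(Cl)ncnc32)c1` gives 1820 nM in this assay. Compound 4 `ClCc1cccc(Cn2cnc3c(Cl)nc(Cl)nc32)c1` has not yet been measured in this assay.

Compound 1 differs from compound 2 by chloro in place of hydrogen on an aromatic carbon, and that change gave an 8.5-fold lower number from compound 2 to compound 1 (0.93 log units; beyond the scatter). Compounds 2 and 3 have the same atoms joined differently; the difference between the two cores is not broken down here. The values of compound 3 and compound 2 lie within the scatter of each other, while compound 3 and compound 1 differ by more than the scatter, compound 1 having the lower number.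

Compound 4 differs from compound 3 by chloro in place of hydrogen on an aromatic carbon. The place of the entering chloro group is described in the same words as for the change from compound 2 to compound 1, so this is the same change made on a core that is joined differently. Among the measured compounds shown here, only one example of the change has been measured, so the expectation rests on a single step, and some allowance is made for it being smaller on the core of compound 3. Compound 4 is estimated at 260 nM in this assay, which means an expected step of a 7.0-fold lower number from compound 3 to compound 4 (0.85 log units; beyond the scatter), set beside the measured 8.5-fold lower number from compound 2 to compound 1 (0.93 log units; beyond the scatter). The expected range for compound 4 runs from 100 nM to 650 nM.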

Compound 4, concentration for 50% growth inhibition: 1690 nM
Beside the measured number, compound 4's estimate is 6.5-fold (0.81 log units) below it; the measured number lies above the stated range.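

In this assay, chloro in place of hydrogen on an aromatic carbon gave a 1.1-fold lower number from compound 3 to compound 4 (0.03 log units; within the scatter), so the step measured on the core of compound 2 did not carry over to the core of compound 3: the same change on two cores in this assay, an 8.5-fold lower number (0.93 log units; beyond the scatter) from compound 2 to compound 1 and a 1.1-fold lower number (0.03 log units; within the scatter) from compound 3 to compound 4, 7.9-fold (0.90 log units) apart, beyond the scatter of two such steps. For this pair of cores, the size of the step therefore depends on the core carrying it, and a single step from one core is a poor guide to the other. The result does not show which feature of the differently joined cores sets the size of the step, and two steps cannot show how the same change would behave on any further core.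

The compounds shown leave open whether another group in the same place between two ring nitrogen atoms, such as an amine or a methoxy group, would separate the two cores in the same way. From the compounds shown here alone, it is also open how each core would respond if the chloromethyl group were replaced by a longer chain or a carboxylic acid.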